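Benzyl ether variation at the saturated-carbon oxygen

The source may report more compounds than this note shows. Statements on the series, on what has been measured and on what is new or still open speak of the compounds shown alone.

Compound 3 `Cc1cc(C)n(CCOC2CC(=O)Nc3c2c(C)nn3-c2ncnc3nc[nH]c23)n1` gives 2000 nM in a functional assay on HEK293 cells for agonist activity at G-protein coupled receptor 39 (Homo sapiens), read by scintillation proximity assay and inositol phosphate accumulation, with a stated time of 75 min (a higher number here means that more compound is needed for the effect, a lower number that less compound is needed), the highest of the three numbers; compound 1 `Cc1nn(-c2ncnc3nc[nH]c23)c2c1C(OCc1ccc(Cl)cc1Cl)CC(=O)N2` gives 243 nM and compound 2 `Cc1nn(-c2ncnc3nc[nH]c23)c2c1C(OC1CCCC1)CC(=O)N2` gives 62 nM. Compound 4 `Cc1nn(-c2ncnc3nc[nH]c23)c2c1C(OCc1ccccc1C#N)CC(=O)N2` carries 2-cyanophenyl in place of (3,5-dimethyl-1H-pyrazol-1-yl)methyl on a saturated chain carbon bound to an oxygen on a saturated carbon. The step that bears most is an 8.2-fold higher number from compound 1 to compound 3 (0.92 log units; beyond the scatter), since compound 1 and compound 4 both hold an aryl group on that chain carbon; a 32-fold higher number from compound 2 to compound 3 (1.51 log units; beyond the scatter) and a 3.9-fold lower number from compound 1 to compound 2 (0.59 log units; beyond the scatter) show the same oxygen substituent spanning a wide range. A move back toward the number of compound 1 is therefore expected, a 6.7-fold lower number from compound 3 to compound 4 (0.82 log units; beyond the scatter), with the 2-cyanophenyl group left open against 2,4-dichlorophenyl. Compound 4 is estimated at 300 nM, range 90 nM to 1000 nM, in this assay.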

Compound 4, half-maximal effective concentration: 127 nM
Beside the measured number, compound 4's estimate is 2.4-fold (0.37 log units) above it; the range from low to high includes it.
By their numbers in this assay, from the lowest: compound 2; then compounds 4 and 1 (each within the scatter of the next); then compound 3.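

In this assay the 2-cyanobenzyl ether stands well apart from the 2-(3,5-dimethyl-1H-pyrazol-1-yl)ethyl ether (a 16-fold lower number from compound 3 to compound 4 (1.20 log units; beyond the scatter)), so the high number of compound 3 is not shared by this second benzyl ether. The two benzyl ethers cannot be separated (a 1.9-fold lower number from compound 1 to compound 4 (0.28 log units; within the scatter)), and 2-cyanophenyl in place of 2,4-dichlorophenyl therefore changes nothing that can be read. Cyclopentyl keeps the lowest number, by a small margin (a 2.0-fold higher number from compound 2 to compound 4 (0.31 log units; beyond the scatter)).

As far as these compounds go, whether an amine, a carboxylic acid or a longer chain ending in phenyl at this oxygen would fall with the benzyl ethers or with compound 3 remains open. No supporting data explain these differences.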